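The source may report more compounds than this note shows. Statements on the series, on what has been measured and on what is new or still open speak of the compounds shown alone.

Compound 3 `Cn1cnc(S(=O)(=O)N2C[C@@H]3[C@H](C2)[C@@]3(CNC(=O)c2ccccc2Cl)CC2CC2)c1` stands lowest of the numbers shown in an assay on isolated protein for inhibition of sodium- and chloride-dependent glycine transporter 1 (Homo sapiens) (a lower number here means a stronger inhibitor, a higher number a weaker inhibitor), with 19 nM. Compound 2 `O=C(NC[C@]1(CC2CC2)[C@@H]2CN(S(=O)(=O)c3cccnc3)C[C@@H]21)c1ccc(Cl)cc1Cl` gives 890 nM in this assay. Compound 1 `O=C(NC[C@]1(CC2CC2)[C@@H]2CN(S(=O)(=O)c3ccccc3F)C[C@@H]21)c1ccc(Cl)cc1Cl` gives > 10000 nM in this assay, which is a limit and not a number (the limit of > 10000 nM in this assay, at which 1 of the 3 values shown sits). Among the measured compounds shown here, the only measured step, an at least 11-fold lower number from compound 1 to compound 2 (1.05 log units; beyond the scatter), concerns the group on the sulfonyl sulfur and so does not touch the amide side that changes in compound 4 `Cn1cnc(S(=O)(=O)N2C[C@@H]3[C@H](C2)[C@@]3(CNC(=O)c2ccc(Cl)cc2)CC2CC2)c1`, which differs from compound 3 by 4-chlorophenyl in place of 2-chlorophenyl on a carbonyl carbon. No measured pair shows the effect of this change, so the estimate rests on no shown comparison and carries a wide range. Compound 4 is expected to be weaker than compound 3, a step of a 7.9-fold higher number from compound 3 to compound 4 (0.90 log units; beyond the scatter). Compound 4 is estimated at 150 nM, between 30 nM and 800 nM.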

Compound 4, half-maximal inhibitory concentration: 32 nM
For compound 4 the middle estimate is 4.7-fold (0.67 log units) above the measured one, and the stated range covers the measured number.
By their numbers in this assay, from the lowest: compounds 3 and 4 (each within the scatter of the next); then compound 2. At a limit, above all of these: compound 1.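

At this place, on a carbonyl carbon whose other neighbour is an amide-type nitrogen, 4-chlorophenyl in place of 2-chlorophenyl gives a 1.7-fold higher number from compound 3 to compound 4 (0.23 log units; within the scatter) in this assay. Among the compounds shown here, the earlier step concerned only the group on the sulfonyl sulfur, so this is the first measured step on the amide side, and here the two chlorophenyl groups cannot be told apart. Nothing given here bears on the reason for this result.

Still open, from the compounds shown here alone, is how an unsubstituted phenyl, a methoxyphenyl or a pyridine ring would behave on this carbonyl carbon.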